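Nitro to chloro swap on two cytotoxicity cores

This account rests on a few compounds, and the source may have more. Where it says the series, first, only, none or still open, it means among the compounds named here.

Compound 1 `CC1=C(C(=O)Nc2ccc(Cl)cc2)C(c2cccc([N+](=O)[O-])c2)C(C(=O)Nc2ccc(Cl)cc2)=C(C)N1` and compound 2 `CC1=C(C(=O)Nc2ccc(Cl)cc2)C(c2cccc(Cl)c2)C(C(=O)Nc2ccc(Cl)cc2)=C(C)N1` share one core; compound 3 `COc1ccc(NC(=O)C2=C(C)NC(=S)NC2c2cccc([N+](=O)[O-])c2)cc1` and compound 4 `COc1ccc(NC(=O)C2=C(C)NC(=S)NC2c2cccc(Cl)c2)cc1` share another. The difference between the two cores is not broken down here. In an ADME assay on Vero cells (Chlorocebus sabaeus) for cytotoxicity, read by sulforhodamine B assay, with a stated time of 3 days (a higher number here means that more compound is tolerated, a lower number that less compound is tolerated), compound 1 gives 26 ug/mL, compound 2 gives 12 ug/mL and compound 3 gives 80 ug/mL, so compound 3 shows the highest number of the three measured, with both gaps beyond the scatter. The change from compound 1 to compound 2 is chloro in place of nitro on an aromatic carbon, and in this assay it reads a 2.2-fold lower number from compound 1 to compound 2 (0.34 log units; beyond the scatter). Compound 4 differs from compound 3 by chloro in place of nitro on an aromatic carbon, the same change at the same kind of place, on an aromatic carbon of a six-membered aromatic ring of carbon only, meta to a large group. Compound 4 has not yet been measured in this assay. Compound 4 is expected to step down by a 2.2-fold lower number from compound 3 to compound 4 (0.35 log units; beyond the scatter), because the same change on the other core gave a 2.2-fold lower number from compound 1 to compound 2 (0.34 log units; beyond the scatter). The estimate for compound 4 in this assay is 36 ug/mL, with a span from 18 ug/mL to 70 ug/mL.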

Compound 4, half-maximal cytotoxic concentration: 270 ug/mL
Compound 4: the middle estimate sits 7.5-fold (0.88 log units) below what was measured, outside the stated range (above it).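

In this assay, chloro in place of nitro on an aromatic carbon reads a 3.4-fold higher number from compound 3 to compound 4 (0.53 log units; beyond the scatter), so the direction seen on the core of compound 1 does not hold on the core of compound 3. The two readings of this one change, made at the same kind of place, differ in direction and by more than the scatter allows: the same change on two cores in this assay, a 2.2-fold lower number (0.34 log units; beyond the scatter) from compound 1 to compound 2 and a 3.4-fold higher number (0.53 log units; beyond the scatter) from compound 3 to compound 4, 7.3-fold (0.86 log units) apart, beyond the scatter of two such steps. This shows that, in this series, the step measured on one core is not a safe guide to the step on the other, but two pairs cannot show which of the differences between the cores goes with the reversal, or give a cause for it.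

Going by these compounds, it remains open whether another group at the same place, such as an amine or a carboxylic acid, would also read differently on the two cores. The compounds shown also leave open which single part of the core of compound 3 sets the higher number of compound 4.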